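The compounds below may be only part of what the source reports. "The series", "measured", "known", "first", "only" and "open" are said of these compounds alone.

Compound 1 `CN(C)CCCNc1nc(-c2ccc(NC(=O)Nc3ccccc3Cl)cc2)nc2ccsc12` and compound 2 `CN(C)CCCNc1nc(-c2ccc(NC(=O)Nc3ccc(Cl)cc3Cl)cc2)nc2ccsc12` share one core and differ only at the outer ring. In a functional assay on MKN-45 cells (Homo sapiens) for cytotoxicity, read by MTT assay, with a stated time of 72 h (a lower number here means a stronger inhibitor, a higher number a weaker inhibitor), compound 1 gives 690 nM, while compound 2 gives 2270 nM. The change between them is chloro in place of hydrogen on an aromatic carbon and it produced a 3.3-fold higher number from compound 1 to compound 2 (0.52 log units; beyond the scatter). Compound 3 `CCN(CC)CCNc1nc(-c2ccc(NC(=O)Nc3ccccc3Cl)cc2)nc2c(Cl)c(Cl)sc12` carries a different core; the difference between the two cores is not broken down here. In this assay compound 3 gives 1130 nM, which lies within the usual scatter of the value of compound 1 and also within the scatter of the value of compound 2. Compound 4 `CCN(CC)CCNc1nc(-c2ccc(NC(=O)Nc3ccc(Cl)cc3Cl)cc2)nc2c(Cl)c(Cl)sc12` is related to compound 3 as compound 2 is to compound 1: the change is chloro in place of hydrogen on an aromatic carbon, the same change as before, at the same place on the outer ring. Compound 4 has not yet been measured in this assay. If the step seen between compound 1 and compound 2 carries over to the other core, compound 4 is expected to show a 3.1-fold higher number from compound 3 to compound 4 (0.49 log units; beyond the scatter), resting on the value of compound 3 and on a 3.3-fold higher number from compound 1 to compound 2 (0.52 log units; beyond the scatter). The estimate for compound 4 is therefore 3500 nM, with a range from 1500 nM to 8000 nM.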

Compound 4, half-maximal inhibitory concentration: 1770 nM
Compound 4: middle estimate off by 2.0-fold (0.30 log units), on the high side; low and high end bracket the measured number.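

In this assay, the change from 2-chlorophenyl to 2,4-dichlorophenyl on the second core gives a 1.6-fold higher number from compound 3 to compound 4 (0.19 log units; within the scatter), a step that stays inside the usual scatter, unlike the step on the first core. Even so, the two steps cannot be told apart, as the gap between them is no larger than two such steps can show by chance: the same change on two cores in this assay, a 3.3-fold higher number (0.52 log units; beyond the scatter) from compound 1 to compound 2 and a 1.6-fold higher number (0.19 log units; within the scatter) from compound 3 to compound 4, 2.1-fold (0.32 log units) apart, within the scatter of two such steps The series is therefore compatible with the change carrying over from one core to the other, but with a single pair on each core it does not establish a shared size for the step, nor does it show that the change has a real effect on the second core.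

The compounds shown leave open whether a fluoro, methyl or methoxy group at the same place on the outer ring would behave alike on both cores. They also leave open how the pair would read with a morpholine or piperidine at the end of the side chain.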